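Ring versus chain on the core nitrogen: estimating compound 4

This account rests on a few compounds, and the source may have more. Where it says the series, first, only, none or still open, it means among the compounds named here.

Among the measured compounds shown here, compound 3 `CC(C)Cn1c(-c2ccc(OCc3c(-c4c(Cl)cccc4Cl)noc3C(C)C)cc2)nc2ccc(C(=O)O)cc21` gives the lowest number so far in an assay on HEK-293T cells for antagonist activity at vitamin D3 receptor (Homo sapiens), read by a luciferase reporter, with a stated time of 24 h (a lower number here means a stronger inhibitor, a higher number a weaker inhibitor), at 1180 nM. Compound 1 `CC(C)c1onc(-c2c(Cl)cccc2Cl)c1COc1ccc(-c2nc3ccc(C(=O)O)cc3n2C2CC2)cc1` gives 3200 nM and compound 2 `CC(C)c1onc(-c2c(Cl)cccc2Cl)c1COc1ccc(-c2nc3ccc(C(=O)O)cc3n2CC2CC2)cc1` gives 2650 nM; the steps from each of these to compound 3 lie beyond the scatter, so compound 3 stands apart from the other two on the numbers shown.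

Compound 4 `CC(C)c1onc(-c2c(Cl)cccc2Cl)c1COc1ccc(-c2nc3ccc(C(=O)O)cc3n2C2CCCC2)cc1` differs from compound 3 by cyclopentyl in place of isobutyl on an aromatic nitrogen. All three measured steps concern a group on this same aromatic nitrogen. The step of a 1.2-fold lower number from compound 1 to compound 2 (0.08 log units; within the scatter) is within the scatter. The steps of a 2.7-fold lower number from compound 1 to compound 3 (0.43 log units; beyond the scatter) and a 2.2-fold lower number from compound 2 to compound 3 (0.35 log units; beyond the scatter) are modest but beyond the scatter, both giving a lower number with isobutyl in place of the smaller groups. For the measured compounds named here, no measured pair compares a five-membered ring with a chain, so the change from isobutyl to cyclopentyl has no direct precedent in this assay, and the only guidance is that compound 3 holds the lowest number of the series.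

Compound 4 is therefore expected to give 1100 nM, in the range 450 nM to 2700 nM. This estimate means a step of a 1.1-fold lower number from compound 3 to compound 4 (0.03 log units; within the scatter) that is expected to remain within the scatter.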

Compound 4, half-maximal inhibitory concentration: 929 nM
Compound 4: middle estimate off by 1.2-fold (0.07 log units), on the high side; low and high end bracket the measured number.
By their numbers in this assay, from the lowest: compounds 4 and 3 (each within the scatter of the next); then compounds 2 and 1 (each within the scatter of the next).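

In this assay, the five-membered ring on this aromatic nitrogen shows that a ring can stand level with the branched chain: a 1.3-fold lower number from compound 3 to compound 4 (0.10 log units; within the scatter) leaves cyclopentyl and isobutyl within the scatter of each other. Cyclopentyl also keeps the separation from the two groups of compounds 1 and 2, with a 2.9-fold lower number from compound 2 to compound 4 (0.46 log units; beyond the scatter) for cyclopentyl in place of cyclopropylmethyl and a 3.4-fold lower number from compound 1 to compound 4 (0.54 log units; beyond the scatter) for cyclopentyl in place of cyclopropyl, both modest but beyond the scatter. The four compounds therefore fall into two pairs, isobutyl with cyclopentyl and cyclopropyl with cyclopropylmethyl, and the presence of a ring alone does not sort them, since cyclopropyl and cyclopentyl are both rings and sit in different pairs.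

As far as these compounds go, whether a cyclohexyl ring, a longer chain or a ring carrying an amine on this aromatic nitrogen would move the number beyond the level of compounds 3 and 4 remains open. No measurement at hand speaks to why these groups separate as they do.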